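Half-life series: the group on the double-bonded carbon

A few compounds are considered here, and "the series" means these few. Any claim that something is new, unique, unknown or untested is made for them only; others in the source may bear on it.

Measured in an ADME assay for pharmacokinetics, read by LC-MS, in phosphate buffer, with a stated time of 120 min, at pH 7.4, tested at 1 uM, in the presence of a further agent that is not named here; a lower number here means that the compound disappears faster, a higher number that the compound lasts longer:
compound 1 `C=C(C(=O)Nc1ccccc1)C(F)(F)F`: 0.25 h
compound 2 `C=C(Cc1ccccc1)C(=O)Nc1ccccc1`: > 8.53 h (a limit)
compound 3 `C=C(F)C(=O)Nc1ccccc1`: > 8.53 h (a limit)

Compound 3 stands at the limit of > 8.53 h in this assay, at which 2 of the 3 values shown sit, so its entry is a limit and not a number. The change to compound 4 `C=C(CN(C)C)C(=O)Nc1ccccc1` is (dimethylamino)methyl in place of fluoro on a double-bonded chain carbon bound to a carbonyl carbon. Within the data shown here, the only measured step at this place is an at least 34-fold higher number from compound 1 to compound 3 (1.53 log units; beyond the scatter), which is large and ends on a limit. Among the measured compounds shown here, compound 1 at 0.25 h shows that a change at this place can give a short half-life, but no measured compound carries (dimethylamino)methyl. A moderate fall is therefore expected in this assay, estimated as an at least 2.1-fold lower number from compound 3 to compound 4 (0.32 log units; beyond the scatter). The expected value for compound 4 is 4 h, with an estimated range of 1 h to 16 h.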

Compound 4, half-life: < 0.0334 h
Compound 4 was reported as a limit; the forecaster's own chance of this, stated with the estimate: 35%; middle value at least 110-fold (2.07 log units) away from the limit.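

In this assay, (dimethylamino)methyl on the double-bonded chain carbon gives an at least 250-fold lower number from compound 3 to compound 4 (2.40 log units; beyond the scatter), and dimethylamino in place of phenyl gives an at least 250-fold lower number from compound 2 to compound 4 (2.40 log units; beyond the scatter). Set against trifluoromethyl, the change gives an at least 7.4-fold lower number from compound 1 to compound 4 (0.87 log units; beyond the scatter), so a short half-life at this position is not confined to trifluoromethyl. Compound 4 stands at a limit and not at a number: the limit of < 0.0334 h in this assay, at which 1 of the 4 values shown sits.

Going by these compounds, whether a primary amine or a carboxylic acid on the saturated chain carbon also gives a short half-life stays open. Compound 2 and compound 3 cannot be ordered, as each entry is a limit: the limit of > 8.53 h in this assay, at which 2 of the 4 values shown sit.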